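A few compounds are considered here, and "the series" means these few. Any claim that something is new, unique, unknown or untested is made for them only; others in the source may bear on it.

Measured so far:
- compound 1, `O=C(CCCCCCn1cc(-c2cccnc2)nn1)Nc1ccccc1-c1ccccc1`: 26.2%
- compound 2, `O=C(CCCCCCn1cc(-c2cccnc2)nn1)Nc1ccccc1Cc1ccccc1`: 28%

In a functional assay on SH-SY5Y cells (Homo sapiens) for cytotoxicity, tested at 1 uM (a lower number here means a stronger effect, a higher number a weaker effect of the compound at the concentration tested), compound 1 gives 26.2% and compound 2 gives 28%. Compound 2 thus has the higher of the two numbers, but the step of a number 1.8 percentage points higher from compound 1 to compound 2 (within the scatter) lies within the scatter, so the two compounds cannot be told apart on this read-out.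

Compound 3, `O=C(CCCCCCn1cc(-c2cccnc2)nn1)Nc1ccccc1Oc1ccccc1`, has not yet been measured. It differs from compound 2 in one place: phenoxy in place of benzyl on an aromatic carbon. Among the compounds with values here, the only step that bears on this change is the one from compound 1 to compound 2, where another group of the same size was swapped at the same position, and it was within the scatter. For compound 3 in this assay the expected step is therefore no change at the digits printed from compound 2 to compound 3 (within the scatter), with no change beyond the scatter in either direction. Compound 3 is estimated at 28%, in the range 14% to 42%.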

Compound 3, a percentage reported as activity, at one concentration (the size of the read-out at that concentration, not a potency): 24.7%
Compound 3: middle estimate off by 3.3 percentage points, on the high side, and the stated range covers the measured number.
By their numbers in this assay, from the lowest: compounds 3, 1 and 2 (each within the scatter of the next).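

In this assay, phenoxy in place of benzyl gives a number 3.3 percentage points lower from compound 2 to compound 3 (within the scatter) at this place, ortho to a large group. Phenoxy in place of phenyl gives a number 1.5 percentage points lower from compound 1 to compound 3 (within the scatter) at the same place. Phenyl, benzyl and phenoxy each carry one six-membered aromatic ring of carbon only, and they cannot be told apart on this read-out, even though phenoxy brings an oxygen and a hydrogen-bond acceptor that benzyl lacks. No measurement at hand explains why these groups read alike.

As far as these compounds go, whether a group without an aromatic ring at this place, such as an amine or a carboxylic acid, would move the number beyond the scatter remains open. The effect of a longer chain in place of phenoxy is open as well.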